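The source may hold more compounds than are shown below. What is called first, only, known or untested is meant among the compounds shown, and "the series" means these compounds.

Compound 1 `O=C(NC[C@H](NS(=O)(=O)c1cccs1)C(=O)O)c1cc2cc(CCC3CCNCC3)sc2s1`: 9 nM
Compound 2 `CCCCS(=O)(=O)N[C@@H](CNC(=O)c1cc2cc(CCC3CCNCC3)sc2s1)C(=O)O`: 32 nM

For the measured compounds named here, in a functional assay for inhibition, with Homo sapiens as the target (on this read-out higher numbers stand for weaker inhibition and lower numbers for stronger inhibition), compound 1 gives 9 nM, the lowest of the two numbers so far and therefore the stronger inhibition. Compound 3 `O=C(O)CCNC(=O)c1cc2cc(CCC3CCNCC3)sc2s1` has not been measured yet. It carries hydrogen in place of ((thiophen-2-yl)sulfonyl)amino on a saturated chain carbon bound to a carbonyl carbon and a saturated chain carbon.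

Going by the values given here, only one measured step bears on this change: a 3.6-fold higher number from compound 1 to compound 2 (0.55 log units; beyond the scatter). That step, butyl in place of thiophen-2-yl on a sulfonyl sulfur, altered only part of the group that compound 3 lacks entirely. Among the compounds with values here, no measured compound lacks the whole group, so the size of this step is uncertain, but a larger rise in this assay seems likely.

The expected change is an 11-fold higher number from compound 1 to compound 3 (1.05 log units; beyond the scatter). For compound 3 the estimated value is 100 nM, with an expected range of 30 nM to 400 nM.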

Compound 3, half-maximal inhibitory concentration: 410 nM
Compound 3: middle estimate off by 4.1-fold (0.61 log units), on the low side, outside the stated range (above it).
By their numbers in this assay, from the lowest: compound 1; then compound 2; then compound 3.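

Removing the whole ((thiophen-2-yl)sulfonyl)amino group from the saturated chain carbon costs far more in this assay than changing only its outer part: hydrogen in its place gives a 46-fold higher number from compound 1 to compound 3 (1.66 log units; beyond the scatter), whereas butyl on the sulfonyl sulfur gave only a 3.6-fold higher number from compound 1 to compound 2 (0.55 log units; beyond the scatter). The same replacement starting from the butyl compound gives a 13-fold higher number from compound 2 to compound 3 (1.11 log units; beyond the scatter), so the loss appears with both sulfonylamino groups shown. At this position, then, either sulfonylamino group gives a much lower number than hydrogen, and the thiophen-2-yl group is not needed to keep most of that advantage.

The compounds shown do not separate the share of the nitrogen from that of the sulfonyl part, which a plain amine on this carbon could help to do. Nothing measured here says why the number rises when the group is lost.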